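Cyclohexylsulfanyl in place of butoxy on a pyridine urea series

A few compounds are considered here, and "the series" means these few. Any claim that something is new, unique, unknown or untested is made for them only; others in the source may bear on it.

Two compounds of this series have been examined so far. Compound 1 `CC1CCN(c2nc(C(F)(F)F)ccc2CNC(=O)Nc2cccc3c2ccc(=O)n3C)CC1` and compound 2 `CCCCOc1nc(C(F)(F)F)ccc1CNC(=O)Nc1cccc2c(=O)[nH]ccc12` share a urea linked to a bicyclic lactam, and differ in the group that sits on the pyridine ring as well as in the lactam. In an assay on CHO cells for agonist activity at transient receptor potential cation channel subfamily V member 1 (Homo sapiens) (a higher number here means that more compound is needed for the effect, a lower number that less compound is needed), compound 1 gives "not active" (no number reported), so no number is reported for it. In this assay compound 2 gives 160 nM, which is the only number shown; the one further entry carries no single number, so there is nothing to rank compound 2 against.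

Compound 3 `O=C(NCc1ccc(C(F)(F)F)nc1SC1CCCCC1)Nc1cccc2c(=O)[nH]ccc12` follows from compound 2 by a single change: cyclohexylsulfanyl in place of butoxy on an aromatic carbon. Within the data shown here, no measured pair shows a step of this kind, so the size of its effect is open. The account expects that the step from compound 2 to compound 3 stays small, a 1.2-fold lower number from compound 2 to compound 3 (0.09 log units; within the scatter), with no clear direction beyond the scatter. Compound 3 is therefore estimated at 130 nM in this assay, with a range from 40 nM to 450 nM.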

Compound 3, half-maximal effective concentration: 69.3 nM
Beside the measured number, compound 3's estimate is 1.9-fold (0.27 log units) above it; measured number inside the range.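

Among these compounds, at this aromatic carbon next to the ring nitrogen, the single change in this assay gives a 2.3-fold lower number from compound 2 to compound 3 (0.36 log units; beyond the scatter) and so provides the first readable step. The position therefore accepts cyclohexylsulfanyl, with 7 heavy atoms and a six-membered non-aromatic ring of carbon only, in place of the open butoxy chain with 5 heavy atoms, and the number in this assay is lower rather than lost. Nothing measured here explains this shift.

The step changes the oxygen to sulfur and the open chain to a ring together, so the compounds shown do not tell which of the two accounts for it; a cyclohexyloxy group or a butylsulfanyl chain on the same carbon would separate them. Going by these compounds, compound 1 gives "not active" (no number reported) but differs from compound 2 and compound 3 in the lactam as well as in this group, so it cannot be read as a step, and how a plain amine at this position would compare remains open.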